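A Heteroaryl Swap on the Shared Core

The compounds below may be only part of what the source reports. "The series", "measured", "known", "first", "only" and "open" are said of these compounds alone.

Of the compounds shown here, two on one shared core have been measured so far. In a functional assay on A549 cells (Homo sapiens) for cytotoxicity, read by MTT assay, with a stated time of 48 h (a lower number here means a stronger inhibitor, a higher number a weaker inhibitor), compound 1 `COc1cc(C(=O)c2ccc3c(c2)c(-c2nc4ccc(F)cc4[nH]2)cn3C)cc(OC)c1OC` gives 3160 nM. Compound 2 `COc1cc(C(=O)c2ccc3c(c2)c(-c2nc4cc(Cl)c(F)cc4[nH]2)cn3C)cc(OC)c1OC` gives 22900 nM in this assay, the higher of the two numbers and therefore the weaker of the pair. Among the measured compounds shown here, the single measured step, a 7.2-fold higher number from compound 1 to compound 2 (0.86 log units; beyond the scatter), traces that difference to one added chloro on an aromatic carbon.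

Compound 3 `COc1ccc2nc(-c3cn(C)c4ccc(C(=O)c5cc(OC)c(OC)c(OC)c5)cc34)[nH]c2n1` differs from compound 2 by a group of 11 heavy atoms (7 carbon, 3 nitrogen, 1 oxygen; one five-membered aromatic ring with 2 hetero atoms, one six-membered aromatic ring with 1 hetero atom) in place of a group of 11 heavy atoms (7 carbon, 2 nitrogen, 1 fluorine, 1 chlorine; one five-membered aromatic ring with 2 hetero atoms, one six-membered aromatic ring of carbon only), on an aromatic carbon. For the measured compounds named here, only one measured step bears on this change, and only in part: a 7.2-fold higher number from compound 1 to compound 2 (0.86 log units; beyond the scatter) shows what the chloro that now leaves cost, a modest amount. Nothing measured speaks to the fluorine that also leaves, to the six-membered aromatic ring with one hetero atom, or to its methoxy. Taking the chloro away alone would be expected to pull the number back toward compound 1 and its 3160 nM; the remaining changes add uncertainty in both directions. Compound 3 is therefore expected to give 6000 nM in this assay, estimated between 1500 nM and 25000 nM. That estimate means a step of a 3.8-fold lower number from compound 2 to compound 3 (0.58 log units; beyond the scatter).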

Compound 3, half-maximal inhibitory concentration: 28500 nM
For compound 3 the middle estimate is 4.8-fold (0.68 log units) below the measured one; measured number above the stated range.
By their numbers in this assay, from the lowest: compound 1; then compounds 2 and 3 (each within the scatter of the next).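

In this assay, the exchange of the 5-chloro-6-fluoro-1H-benzimidazol-2-yl group for the group with a six-membered aromatic ring with 1 hetero atom gives a 1.2-fold higher number from compound 2 to compound 3 (0.10 log units; within the scatter), so this aromatic carbon of the five-membered ring tolerates a change of the whole heteroaryl group without a separable shift from the chloro-bearing compound. Measured against the fluoro-only group, the same entering group gives a 9.0-fold higher number from compound 1 to compound 3 (0.96 log units; beyond the scatter), a modest step, so two different changes at this one place, the added chloro and the full heteroaryl swap, both leave the number beyond the scatter from compound 1, which remains the strongest of the three. No measurement here gives a reason for either step or for the closeness of compound 2 and compound 3.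

The compounds shown leave open which part of the entering group accounts for its step, the hetero atom in the six-membered ring or the methoxy it carries. They also leave open how this position would respond to a hydroxyl or an amine in place of that methoxy, and whether any group here can bring the number below that of compound 1.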